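Swapping a chloromethylphenyl group for a difluorophenyl group

The source may report more compounds than this note shows. Statements on the series, on what has been measured and on what is new or still open speak of the compounds shown alone.

Measured in an in vitro ADME assay on microsomes from liver (Homo sapiens) for pharmacokinetics, read by LC-MS, with a stated time of 10 min, tested at 1 uM; a lower number here means slower removal, a higher number faster removal of the compound:
- Compound 1 `CN1C[C@H](C(=O)Nc2ccc(F)cc2)[C@@H](c2ccc(/C=C/C(=O)Nc3ccccc3N)cc2)C1` gives 5 mL/min/kg
- Compound 2 `CN1C[C@H](C(=O)Nc2ccccc2F)[C@@H](c2ccc(/C=C/C(=O)Nc3ccccc3N)cc2)C1` gives 10 mL/min/kg
- Compound 3 `Cc1cc(NC(=O)[C@H]2CN(C)C[C@@H]2c2ccc(/C=C/C(=O)Nc3ccccc3N)cc2)ccc1Cl` gives 15 mL/min/kg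

Compound 3 cannot be told apart from compound 2 on these numbers, as the difference lies within the scatter (a 1.5-fold higher number from compound 2 to compound 3 (0.18 log units; within the scatter)). It does stand apart from compound 1, though only modestly (a 3.0-fold higher number from compound 1 to compound 3 (0.48 log units; beyond the scatter)).

Compound 4 `CN1C[C@H](C(=O)Nc2ccc(F)cc2F)[C@@H](c2ccc(/C=C/C(=O)Nc3ccccc3N)cc2)C1` keeps the shared core and changes one group, with 2,4-difluorophenyl in place of 4-chloro-3-methylphenyl on an amide-type nitrogen.

The nearest guides are compound 1, with its 4-fluorophenyl group, and compound 2, with its 2-fluorophenyl group. The new group carries fluorine at both of those positions, and moving between those two single placements gave a step within the scatter (a 2.0-fold higher number from compound 1 to compound 2 (0.30 log units; within the scatter)). For the measured compounds named here, no measured compound carries both fluorines, so how they combine is unknown. Compound 4 is expected to land near compound 1 and compound 2 rather than beyond them.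

In this assay the step is expected to be a 1.7-fold lower number from compound 3 to compound 4 (0.22 log units; within the scatter). The estimate for compound 4 is 9 mL/min/kg (expected range 4 mL/min/kg to 20 mL/min/kg).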

Compound 4, clearance: 12 mL/min/kg
Beside the measured number, compound 4's estimate is 1.3-fold (0.12 log units) below it; the range from low to high includes it.
By their numbers in this assay, from the lowest: compounds 1, 2, 4 and 3 (each within the scatter of the next, the first and the last beyond it).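

In this assay, replacing 4-chloro-3-methylphenyl with 2,4-difluorophenyl on the amide-type nitrogen leaves clearance indistinguishable, even though the chlorine and methyl give way to two fluorines (a 1.3-fold lower number from compound 3 to compound 4 (0.10 log units; within the scatter)). For the compounds shown here, the result also allows the first reading of fluoro in place of hydrogen on an aromatic carbon at this group: added to the 2-fluorophenyl group of compound 2, the change cannot be told from no change (a 1.2-fold higher number from compound 2 to compound 4 (0.08 log units; within the scatter)), whereas added to the 4-fluorophenyl group of compound 1, it gives a modest rise that does stand clear of the scatter (a 2.4-fold higher number from compound 1 to compound 4 (0.38 log units; beyond the scatter)). Nothing shown here gives a reason for these numbers, so the figures record what happened at this position without explaining it.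

As far as these compounds go, all four compounds carry a halogen-bearing phenyl ring at this position, so it remains open how the same read-out would respond to an unsubstituted phenyl ring or to a ring bearing a methoxy group, a nitrile or a carboxylic acid. From the compounds shown here alone, it is also open whether compound 1 would stay at the low end of this small set once such groups are compared with its 4-fluorophenyl group.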